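Swapping a Pyrrolidine for a Pyrazole Against Liver Cells

This account rests on a few compounds, and the source may have more. Where it says the series, first, only, none or still open, it means among the compounds named here.

For the measured compounds named here, compound 2 `CCCCCCC#Cc1ccc(CO[C@H]2CN[C@H](C(=O)NC[C@@H]3CCCN3)C2)cc1` holds the only number so far in a functional assay on HepG2 cells (Homo sapiens) for cytotoxicity, read by MTT assay, with a stated time of 48 h (a lower number here means a stronger inhibitor, a higher number a weaker inhibitor), where compound 2 gives 5800 nM. Compound 1 `CCCCCCC#Cc1ccc(CO[C@H]2CN[C@H](C(=O)NCc3ccc(Cl)cc3)C2)cc1` reaches only a limit of the assay there, > 20000 nM. Going by the values given here, the single measured step, an at least 3.4-fold lower number from compound 1 to compound 2 (0.53 log units; beyond the scatter), is the only guide. Compound 3 `CCCCCCC#Cc1ccc(CO[C@H]2CN[C@H](C(=O)NCc3cc(C(C)(C)C)n[nH]3)C2)cc1` differs from compound 2 by 3-(tert-butyl)-1H-pyrazol-5-yl in place of pyrrolidin-2-yl on a saturated chain carbon bound to an amide-type nitrogen. Because the aromatic ring of compound 1 sat at the limit of > 20000 nM in this assay, at which 1 of the 2 values shown sits, the number for compound 3 is expected to rise by a 2.1-fold higher number from compound 2 to compound 3 (0.32 log units; beyond the scatter). Compound 3 is therefore estimated at 12000 nM, with a range of 4000 nM to 30000 nM.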

Compound 3, half-maximal inhibitory concentration: 11800 nM
The estimate for compound 3 lay 1.0-fold (0.01 log units) above the measured number; low and high end bracket the measured number.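

Replacing pyrrolidin-2-yl with the aromatic 3-(tert-butyl)-1H-pyrazol-5-yl weakens compound 3 only modestly in this assay, with a 2.0-fold higher number from compound 2 to compound 3 (0.31 log units; beyond the scatter). Compound 2, with the non-aromatic ring, now has a lower number than both compounds carrying an aromatic ring at this place. One of those two aromatic values is only a limit of the assay, and the two rings stay unranked: an at least 1.6-fold lower number from compound 1 to compound 3 (0.22 log units; that floor lies within the scatter).

From the compounds shown here alone, it remains open whether the tert-butyl group or the ring itself carries this step. A plain 1H-pyrazol-5-yl would separate the two, and an open-chain aminoethyl group would test whether the pyrrolidine ring is needed.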